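The source may report more compounds than this note shows. Statements on the series, on what has been measured and on what is new or still open speak of the compounds shown alone.

Compound 2, `C[Se]/C(=N\C(=O)c1ccno1)NC(=O)c1ccno1`, carries a methylselanyl-type group on a carbon doubly bonded to nitrogen, and in a functional assay on PC-3 cells (Homo sapiens) for cytotoxicity, read by MTT assay, with a stated time of 72 h (on this read-out higher numbers stand for weaker inhibition of growth and lower numbers for stronger inhibition of growth), compound 2 gives 90 nM. Its sulfur counterpart, compound 1, `CS/C(=N\C(=O)c1ccno1)NC(=O)c1ccno1`, gives 99200 nM in this assay. The change between them, (a group of 2 heavy atoms (1 carbon, 1 sulfur; no ring) in place of a group of 2 heavy atoms (1 carbon, 1 selenium; no ring), on a carbon with a double bond to nitrogen), produced a 1100-fold higher number from compound 2 to compound 1 (3.04 log units; beyond the scatter). Compound 3, `C[Se]/C(=N\C(=O)c1cnc2ccccc2c1)NC(=O)c1cnc2ccccc2c1`, keeps the selenium group but on a different core; the difference between the core of compound 3 and that of compound 2 is not broken down here. In this assay compound 3 gives 2330 nM.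

Compound 4, `CS/C(=N\C(=O)c1cnc2ccccc2c1)NC(=O)c1cnc2ccccc2c1`, is the unmeasured counterpart of compound 3, related to it by a group of 2 heavy atoms (1 carbon, 1 sulfur; no ring) in place of a group of 2 heavy atoms (1 carbon, 1 selenium; no ring), on a carbon with a double bond to nitrogen, the same change that led from compound 2 to compound 1. Because a 1100-fold higher number from compound 2 to compound 1 (3.04 log units; beyond the scatter) was large, the step from compound 3 to compound 4 is expected to be of similar direction and magnitude, estimated as a 43-fold higher number from compound 3 to compound 4 (1.63 log units; beyond the scatter), though the top of the tested range may cap what can be reported. The value for compound 4 in this assay is therefore estimated at 100000 nM, expected to lie between 20000 nM and 400000 nM.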

Compound 4, concentration for 50% growth inhibition: 76300 nM
Compound 4: the middle estimate sits 1.3-fold (0.12 log units) above what was measured; the measured number falls inside the stated range.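

In this assay, exchanging the selenium-bearing group for methylsulfanyl on the core of compound 3 gives a 33-fold higher number from compound 3 to compound 4 (1.52 log units; beyond the scatter), so the number rises on this core as it did on the core of compound 2. The direction of the change therefore carries over, but its size does not, as the two steps stand clearly apart: the same change on two cores in this assay, a 1100-fold higher number (3.04 log units; beyond the scatter) from compound 2 to compound 1 and a 33-fold higher number (1.52 log units; beyond the scatter) from compound 3 to compound 4, 34-fold (1.53 log units) apart, beyond the scatter of two such steps. Two cores show that the size of this step depends on the core in this pair of examples, but they give no rule for predicting the size on a further core, and they do not show which feature of the core sets it.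

The compounds shown leave open whether a longer chain, such as ethyl in place of the methyl on the selenium or the sulfur, would preserve the gap between the two elements. They also leave open how the step would behave if an amine replaced that group altogether, or in cell lines other than this one.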